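This account rests on a few compounds, and the source may have more. Where it says the series, first, only, none or still open, it means among the compounds named here.

Measured compounds: compound 1 `COc1cc(-c2cc(/C=C/C(=O)c3ccc(C)cc3)nc3cc(-c4ccccc4)nn23)cc(OC)c1OC` gives 50400 nM; compound 2 `COc1cc(-c2cc(/C=C/C(=O)c3ccccc3)nc3cc(-c4ccccc4)nn23)cc(OC)c1OC` gives >= 100000 nM.

In an ADME assay on HEK293 cells (Homo sapiens) for antiproliferative activity, read by MTT assay, with a stated time of 24 h (on this read-out higher numbers stand for weaker inhibition and lower numbers for stronger inhibition), compound 1 gives 50400 nM. In this assay compound 2 gives only a limit of the assay, >= 100000 nM. Among the measured compounds shown here, the one measured step, an at least 1.9-fold higher number from compound 1 to compound 2 (0.29 log units; that floor lies within the scatter), removed a methyl from the benzoyl ring, and compound 2 sits at the limit of >= 100000 nM in this assay, at which 1 of the 2 values shown sits, so its number is known only as a floor and it stands at the weak end of what has been seen.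

Compound 3 `COc1ccc(/C=C/C(=O)c2cc(-c3cc(OC)c(OC)c(OC)c3)n3nc(-c4ccccc4)cc3n2)cc1` differs from compound 2 in one place: (2-(4-methoxyphenyl)ethenyl)carbonyl in place of 2-benzoylethenyl on an aromatic carbon. This puts a substituent back onto the same six-membered ring from which the methyl was taken in the step from compound 1 to compound 2. For the measured compounds named here, that step is the only one bearing on the change, and it was at the edge of the scatter. A step of similar size in the opposite direction is therefore expected for compound 3, an at least 1.6-fold lower number from compound 2 to compound 3 (0.22 log units; that floor lies within the scatter), with compound 3 estimated at 60000 nM, between 25000 nM and 150000 nM, with a fair chance that only a limit is reported.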

Compound 3, half-maximal inhibitory concentration: 46600 nM
Estimate against measurement, compound 3: 1.3-fold (0.11 log units) above; measured number inside the range.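

At this aromatic carbon, next to the ring nitrogen, replacing 2-benzoylethenyl with (2-(4-methoxyphenyl)ethenyl)carbonyl gives in this assay an at least 2.1-fold lower number from compound 2 to compound 3 (0.33 log units; beyond the scatter), so a change at this position now produces a step beyond the scatter, which the removal of the methyl did not. Set against 2-((4-methylphenyl)carbonyl)ethenyl, the same entering group gives a 1.1-fold lower number from compound 1 to compound 3 (0.03 log units; within the scatter), so these two groups cannot be told apart on this read-out even though their carbonyls stand at different places in the chain. Compound 2 remains a limit of the assay, so the first of these two steps is only a floor: the limit of >= 100000 nM in this assay, at which 1 of the 3 values shown sits.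

The entering group differs from the one it replaces both in where its carbonyl stands and in its methoxy group, and the compounds shown do not separate these two changes. From the compounds shown here alone, it also remains open whether an amine or a carboxylic acid on the outer phenyl ring, or a longer chain in place of the ethenyl, would move the number any further from those seen so far.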